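The source may report more compounds than this note shows. Statements on the series, on what has been measured and on what is new or still open speak of the compounds shown alone.

Measured so far:
- Compound 1 `Cc1ccccc1-c1nn(-c2ccc(F)c(F)c2)cc1CNCCN1CCN(C)CC1`: > 20000 nM
- Compound 2 `Cc1ccccc1-c1nn(-c2ccc(F)cc2F)cc1CN1CCC(N2CCCCC2)CC1`: > 20000 nM
- Compound 3 `COC(=O)c1ccc(-c2nn(-c3ccc(F)cc3F)cc2CNCCN2CCN(C)CC2)cc1`: > 20000 nM

All three values come from an ADME assay on Huh-7 cells (Homo sapiens) for cytotoxicity; on this read-out higher numbers stand for lower toxicity in this test and lower numbers for higher toxicity in this test. Each of them is a limit of the assay rather than a number: the cells tolerated the highest concentration tested, so no half-maximal concentration could be read. Compound 1 therefore stands at the limit of > 20000 nM in this assay, at which 3 of the 3 values shown sit, together with the other two compounds, and nothing in these numbers sets one compound apart from another.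

The compound still to be measured is compound 4 `Cc1ccccc1-c1nn(-c2ccc(N)cc2)cc1CNCCN1CCN(C)CC1`. Compared with compound 1 the change is 4-aminophenyl in place of 3,4-difluorophenyl on an aromatic nitrogen. The rest of the molecule, including the shared core and the chain with its ring, is kept as in compound 1.

Within the data shown here, no step between two measured compounds is known here, so the size of this change on the read-out cannot be taken from a measured pair. Given that compound 1, compound 2 and compound 3 all sit at the limit, the expected step that the limit leaves unreadable from compound 1 to compound 4 is none beyond the usual scatter, and the most likely outcome is again a limit. The estimate for compound 4 in this assay is 25000 nM, expected to fall between 10000 nM and 60000 nM.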

Compound 4, half-maximal cytotoxic concentration: > 20000 nM
Compound 4 ended at the assay's limit; the forecaster's own chance of this, stated with the estimate: 70%; the middle value is on the limit's open side.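

In this assay compound 1 and compound 4 each give a limit rather than a number, so no step can be read for 4-aminophenyl in place of 3,4-difluorophenyl: the limit of > 20000 nM in this assay, at which 4 of the 4 values shown sit.

The compounds shown leave open how far each one lies from that limit, and so whether this change on the aromatic nitrogen alters the read-out at all.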